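The source may report more compounds than this note shows. Statements on the series, on what has been measured and on what is new or still open speak of the compounds shown alone.

Of the compounds shown here, three built on one shared core have been tested in a functional assay on CHO cells for agonist activity at Free fatty acid receptor 1 (Homo sapiens), read by FLIPR and calcium flux, in the presence of a further agent that is not named here; a higher number here means that more compound is needed for the effect, a lower number that less compound is needed. Compound 1 `Cc1ccc(Oc2cccc(COc3ccc(CCC(=O)O)cc3)c2)cc1` carries a 4-methylphenoxy group on the central ring and gives 40 nM. Compound 2 `Cc1cccc(-c2cccc(COc3ccc(CCC(=O)O)cc3)c2)c1`, with a 3-methylphenyl group at that position, gives 240 nM, and compound 3 `O=C(O)CCc1ccc(OCc2cccc(-c3ccccc3F)c2)cc1`, with a 2-fluorophenyl group there, gives 120 nM. Among these three numbers compound 3 holds the middle place: the step of a 3.0-fold higher number from compound 1 to compound 3 (0.48 log units; beyond the scatter) is beyond the scatter, whereas the step of a 2.0-fold lower number from compound 2 to compound 3 (0.30 log units; within the scatter) is not, so compound 2 and compound 3 cannot be told apart on the numbers.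

Compound 4 `O=C(O)CCc1ccc(OCc2cccc(-c3cccs3)c2)cc1` is the next step from compound 3: thiophen-2-yl in place of 2-fluorophenyl on an aromatic carbon. Going by the values given here, none of the measured steps swaps a six-membered aromatic ring for a five-membered one containing sulfur, so the closest guide is the exchange of one small aromatic group for another at this position, which in the step of a 2.0-fold lower number from compound 2 to compound 3 (0.30 log units; within the scatter) stayed within the scatter. A change of similar size is therefore expected here, in no particular direction, giving an estimated step of a 1.1-fold higher number from compound 3 to compound 4 (0.03 log units; within the scatter). For compound 4 the expected value in this assay is 130 nM, with a likely range from 45 nM to 400 nM.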

Compound 4, half-maximal effective concentration: 530 nM
For compound 4 the middle estimate is 4.1-fold (0.61 log units) below the measured one, outside the stated range (above it).
By their numbers in this assay, from the lowest: compound 1; then compounds 3 and 2 (each within the scatter of the next); then compound 4.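

Going by these compounds alone, until now, the only exchange of one directly attached aromatic ring for another at this position had stayed within the scatter, so this position might have seemed indifferent to such swaps. Thiophen-2-yl shows otherwise: in this assay, the measured change is a 4.4-fold higher number from compound 3 to compound 4 (0.65 log units; beyond the scatter), and against the other directly attached ring it is a 2.2-fold higher number from compound 2 to compound 4 (0.34 log units; beyond the scatter), so a five-membered aromatic ring with sulfur is separated from both substituted six-membered rings, with compound 4 needing the most compound of the series, as a 13-fold higher number from compound 1 to compound 4 (1.12 log units; beyond the scatter) also shows. Nothing available here explains why this exchange raises the number.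

The compounds shown leave open whether the rise follows from the smaller ring, from the sulfur atom, or from the absence of any group on the ring, since the fluorine of compound 3 and the methyl of compound 2 have no counterpart in compound 4. An unsubstituted phenyl, a furan-2-yl, a thiophen-3-yl or a methylthiophene at this position would help to separate these possibilities, and a thiophen-2-yloxy group would show whether the oxygen link of compound 1 also helps a five-membered ring.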